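The source may hold more compounds than are shown below. What is called first, only, known or untested is meant among the compounds shown, and "the series" means these compounds.

In a functional assay on HOP-62 cells (Homo sapiens) for inhibition, read by sulforhodamine B assay, with a stated time of 48 h (on this read-out lower numbers stand for higher toxicity in this test and higher numbers for lower toxicity in this test), compound 2 `COc1cc(-c2nn(-c3cccc(NC(=O)Nc4ccc(Cl)c(Cl)c4)c3)cc2-c2ccncc2)ccc1Cl` gives > 50000 nM, which is a limit and not a number. Compound 1 `O=C(Nc1cccc(-n2cc(-c3ccncc3)c(-c3ccc(Cl)c(O)c3)n2)c1)Nc1cccc(C(F)(F)F)c1` gives > 32500 nM, likewise a limit. Compound 3 `O=C(Nc1cccc(-n2cc(-c3ccncc3)c(-c3ccc(Cl)c(O)c3)n2)c1)Nc1ccc(Cl)c(Cl)c1` gives > 32500 nM, also a limit. None of the three therefore has a read number.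

Compound 4 `COc1cc(-c2nn(-c3cccc(NC(=O)c4ccc(Cl)c(C(F)(F)F)c4)c3)cc2-c2ccncc2)ccc1Cl` differs from compound 2 in one place: 4-chloro-3-(trifluoromethyl)phenyl in place of (3,4-dichlorophenyl)amino on a carbonyl carbon. In words, 4-chloro-3-(trifluoromethyl)phenyl stands in place of (3,4-dichlorophenyl)amino on a carbonyl carbon.

Two measured steps lie nearest to this change. For the measured compounds named here, the first is a step that the two limits leave unreadable from compound 1 to compound 3, with 3,4-dichlorophenyl in place of 3-(trifluoromethyl)phenyl on an amide-type nitrogen. The second is a step that the two limits leave unreadable from compound 2 to compound 3, with hydrogen in place of methyl on an oxygen on an aromatic ring. Neither has a readable size, and neither makes the replacement on the carbonyl carbon that separates compound 4 from compound 2.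

The expectation therefore rests on compound 2 and its limit of > 50000 nM. No step beyond the scatter is expected in this assay, in either direction, and another limit is the likeliest report. The estimated change is a number no higher from compound 2 to compound 4 (the limit leaves the size open). For compound 4 the expected value is 50000 nM, with an estimated range from 15000 nM to 100000 nM.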

Compound 4, concentration lethal to 50% of the cells: > 32500 nM
Compound 4: no number, only a limit; the forecaster's own chance of this, stated with the estimate: 75%; the middle value lies beyond the limit too.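

In this assay compound 4 gives > 32500 nM, which is a limit and not a number. Compound 2 gives > 50000 nM, also a limit, so no step can be read between compound 2 and compound 4. The compounds shown leave open whether this replacement on the carbonyl carbon changes the read-out at all, and where any of the four would give a read number.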